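From Hydroxy to Benzyloxycarbonyl on the Shared Core

The compounds below may be only part of what the source reports. "The series", "measured", "known", "first", "only" and "open" are said of these compounds alone.

Compound 1 `O=C(CN(c1ncnc2c1ncn2C1CCCCO1)C1CC1)N[C@@H](CO)C(=O)OCc1ccccc1` and compound 2 `O=C(O)C[C@H](NC(=O)CN(c1nc(Cl)nc2[nH]cnc12)C1CC1)C(=O)O` were both tested in a functional assay on the whole organism (Tail, strain ICR) with Mus musculus as the target, in the tail flick test, with a stated time of 150 min, at a dose of 25 umol/kg by the oral route; a lower number here means a weaker effect, a higher number a stronger effect of the compound at the dose given. In this assay compound 1 gives 18.3%, and compound 2 gives 11.6%. Compound 1 holds the higher of the two numbers, yet the gap to compound 2 lies within the usual scatter, so the two cannot be put in order. Among the compounds with values here, no pair of measured compounds differing at a single point is available to show the size of any step.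

Compound 3 `O=C(CN(c1ncnc2c1ncn2C1CCCCO1)C1CC1)N[C@@H](CC(=O)OCc1ccccc1)C(=O)OCc1ccccc1` has not yet been measured in this assay. It differs from compound 1 as follows: benzyloxycarbonyl in place of hydroxy on a saturated chain carbon, two bonds along the chain from an amide-type nitrogen and a carbonyl carbon. With two low values that sit within the scatter of each other, there is no basis for expecting a directed change, and the step of a number 0.3 percentage points lower from compound 1 to compound 3 (within the scatter) is expected to stay within the scatter. Compound 3 is therefore estimated to give 18% in this assay, with a range from 5% to 35%.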

Compound 3, a percentage reported as activity, at one dose (the size of the read-out at that dose, not a potency): 0.06%
Beside the measured number, compound 3's estimate is 17.9 percentage points above it, outside the stated range (below it).
By their numbers in this assay, from the lowest: compound 3; then compounds 2 and 1 (each within the scatter of the next).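

In this assay, within the data shown here, replacing hydroxy with benzyloxycarbonyl on a saturated chain carbon, two bonds along the chain from an amide-type nitrogen and a carbonyl carbon, gives a number 18.2 percentage points lower from compound 1 to compound 3 (beyond the scatter), the first step at a single place that can be read. This shows that the effect at the dose given depends on what this position carries, and that this change leaves compound 3 with almost none, at 0.06% in this assay. No measurement bearing on the reason for this loss is available.

Among these compounds, the single step cannot separate the loss of the hydroxy group from the arrival of the benzyloxycarbonyl group with its aromatic ring. Going by these compounds, whether an amine or a methyl ester at this position would hold the level of compound 1 remains open.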